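The compounds below may be only part of what the source reports. "The series", "measured", "known", "first", "only" and "open" are said of these compounds alone.

Measured compounds:
Compound 1 `Cc1nc(N(C)c2ccc([Se]C#N)c(Cl)c2)c2ccccc2n1` gives 12 nM in a functional assay on HepG2 cells (Homo sapiens) for inhibition, read by MTT assay, with a stated time of 48 h; a lower number here means a stronger inhibitor, a higher number a weaker inhibitor.
Compound 2 `COc1ccc(N(C)c2nc(C)nc3ccccc23)cc1C(=O)NCC[Se]C#N` gives 179 nM in this assay.
Compound 3 `COc1ccc(N(C)c2nc(C)nc3ccccc23)cc1C(=O)OCCCCC[Se]C#N` gives 667 nM in this assay.

Compound 1 stands lowest of the three numbers; compound 2 is nearest and compound 3 furthest, both gaps beyond the scatter. Compound 4 `Cc1nc(N(C)c2ccc([Se]C#N)c(F)c2)c2ccccc2n1` differs from compound 1 in one place: fluoro in place of chloro on an aromatic carbon. Going by the values given here, the only measured step, a 3.7-fold higher number from compound 2 to compound 3 (0.57 log units; beyond the scatter), concerns a change on a carbonyl carbon and does not bear on a halogen swap on the aromatic ring, so no measured step guides this change. A swap of one halogen for another of this kind is therefore expected to give a small step in this assay, most likely within the scatter, with the direction uncertain. Compound 4 is estimated at 20 nM, in a range of 7 nM to 60 nM, a step of a 1.7-fold higher number from compound 1 to compound 4 (0.22 log units; within the scatter).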

Compound 4, half-maximal inhibitory concentration: 37 nM
The estimate for compound 4 lay 1.9-fold (0.27 log units) below the measured number, and the stated range covers the measured number.
By their numbers in this assay, from the lowest: compound 1; then compound 4; then compound 2; then compound 3.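

Going by these compounds alone, the halogen on this aromatic carbon makes a difference in this assay that the earlier compounds could not show. Fluoro in place of chloro gives a 3.1-fold higher number from compound 1 to compound 4 (0.49 log units; beyond the scatter) and so goes beyond the scatter, even though only a single heavy atom changes. Nothing measured here explains this step.

As far as these compounds go, whether bromo or trifluoromethyl on the same carbon would extend the order seen for chloro and fluoro remains open. So does whether the same swap would give a similar step on another core.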